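The compounds below may be only part of what the source reports. "The series", "measured", "known", "first", "only" and "open" are said of these compounds alone.

Compounds and values:
- Compound 1 `Cn1cc(-c2cnc3ccnc(N)c3c2)cn1`: 33400 nM
- Compound 2 `Cn1cc(-c2cnc3ccnc(NC(=O)C4CC4)c3c2)cn1`: > 50000 nM, a limit
- Compound 3 `Cn1cc(-c2cnc3ccnc(NC(=O)c4ccc(F)cc4)c3c2)cn1`: > 50000 nM, a limit
- Compound 4 `CCNc1nccc2ncc(-c3cnn(C)c3)cc12`: not yet measured

These values come from a functional assay on A549 cells (Homo sapiens) for antiproliferative activity, read by MTT assay, with a stated time of 48 h; on this read-out higher numbers stand for weaker inhibition and lower numbers for stronger inhibition. Compound 2 gives no number, and it stands at the limit of > 50000 nM in this assay, at which 2 of the 3 values shown sit. The change followed here is ethyl in place of cyclopropylcarbonyl on a nitrogen on an aromatic ring, with ethyl in place of cyclopropylcarbonyl on a nitrogen on an aromatic ring, and it leads to compound 4.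

The closest measured change falls on the same nitrogen: an at least 1.4-fold higher number from compound 1 to compound 2 (0.17 log units; that floor lies within the scatter). The other measured change gives a step that the two limits leave unreadable from compound 2 to compound 3, so it offers no usable size. Compound 4 carries no carbonyl on that nitrogen, and neither does compound 1, at 33400 nM. A modest move toward a lower number in this assay is therefore expected, though it may not clear the scatter. The expected change is an at least 1.7-fold lower number from compound 2 to compound 4 (0.25 log units; that floor lies within the scatter). For compound 4 the estimated value is 28000 nM, with an expected range of 12000 nM to 50000 nM.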

Compound 4, half-maximal inhibitory concentration: 40700 nM
The estimate for compound 4 lay 1.5-fold (0.16 log units) below the measured number; the range from low to high includes it.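

With ethyl on this nitrogen, this assay returns a number for compound 4 rather than a limit, and the step against hydrogen is a 1.2-fold higher number from compound 1 to compound 4 (0.09 log units; within the scatter), so ethyl and hydrogen cannot be told apart at this position. The step against cyclopropylcarbonyl is an at least 1.2-fold lower number from compound 2 to compound 4 (0.08 log units; that floor lies within the scatter), so the floor of this change does not separate ethyl from the amide. Compound 2 itself gives a limit and not a number: the limit of > 50000 nM in this assay, at which 2 of the 4 values shown sit.

The compounds shown leave open whether a longer chain or a benzyl group on this nitrogen, or a chain ending in an amine, would move the value beyond the scatter from compound 1. They also leave open the true value of compound 2, and with it the full size of the step to ethyl.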